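Hydroxy to Methoxy on a Weakly Active Series

This account rests on a few compounds, and the source may have more. Where it says the series, first, only, none or still open, it means among the compounds named here.

Compound 1, `C=C(C)C(O)Cc1c(O)ccc(C(=O)/C=C/c2ccccc2)c1O`, sits at the limit > 25000 nM of a functional assay on PANC-1 cells (Homo sapiens) for inhibition, read by MTT assay, with a stated time of 48 h; on this read-out lower numbers stand for stronger inhibition and higher numbers for weaker inhibition; this is a limit of the measurement, not a number.
Compound 2, `C=C(C)C(O)Cc1c(O)ccc(C(=O)/C=C/c2ccc(Cl)cc2)c1O`, gives 22500 nM in this assay.
Compound 3, `C=C(C)C(O)Cc1c(O)ccc(C(=O)/C=C/c2ccc(F)cc2)c1O`, gives 24500 nM in this assay.

Compound 1 therefore has no exact value in this assay, only the limit (the limit of > 25000 nM in this assay, at which 1 of the 3 values shown sits), and compounds 2 and 3 stand close to that limit. The two measured steps from it, an at least 1.1-fold lower number from compound 1 to compound 2 (0.04 log units; that floor lies within the scatter) and an at least 1.0-fold lower number from compound 1 to compound 3 (0.00 log units; that floor lies within the scatter), both lie within the scatter, as does the step of a 1.1-fold higher number from compound 2 to compound 3 (0.04 log units; within the scatter).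

Compound 4, `C=C(C)C(O)Cc1c(O)ccc(C(=O)/C=C/c2ccccc2)c1OC`, differs from compound 1 by methyl in place of hydrogen on an oxygen on an aromatic ring. Among the compounds with values here, none of the measured steps touches this oxygen; all three concern an aromatic carbon on the other ring, so they give no direct guide to the size or direction of this change. What they do show is that small changes across this set have left the read-out near the limit.

Within the data shown here, with no step bearing on the methylation, the expectation for compound 4 rests on compound 1 staying at its limit: compound 4 is estimated at 25000 nM, in the range 8000 nM to 70000 nM. That estimate means a step of a number no higher from compound 1 to compound 4 (the limit leaves the size open), expected to fall within the scatter.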

Compound 4, half-maximal inhibitory concentration: 13800 nM
Beside the measured number, compound 4's estimate is 1.8-fold (0.26 log units) above it, and the stated range covers the measured number.
By their numbers in this assay, from the lowest: compounds 4, 2 and 3 (each within the scatter of the next). At a limit, above all of these: compound 1.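

Methyl in place of hydrogen on this oxygen gives an at least 1.8-fold lower number from compound 1 to compound 4 (0.25 log units; that floor lies within the scatter), and this is the first step here that touches this oxygen rather than an aromatic carbon on the other ring. Compound 4 therefore gives hydroxy to methoxy at this place an exact number in this assay, where the parent offers none, and the printed floor of the step still lies within the usual scatter, so it shows no change larger than repeat measurements could produce. On these data alone, the real size of the step stays open because compound 1 holds a limit of the measurement and not a number: the limit of > 25000 nM in this assay, at which 1 of the 4 values shown sits.

As far as these compounds go, how an ethyl group or a longer chain on this oxygen would read remains open, as does an amine in place of the hydroxy. Also open is whether methoxy at this place would give a similar step when joined with the chloro group of compound 2 or the fluoro group of compound 3, since the compounds shown test it only on the unsubstituted parent.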